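The compounds below may be only part of what the source reports. "The series", "measured", "known", "first", "only" and "open" are said of these compounds alone.

Working notes on the series, read in a functional assay on MDA-MB-231 cells (Homo sapiens) for inhibition, read by CCK-8 assay, with a stated time of 48 h; on this read-out lower numbers stand for stronger inhibition of growth and higher numbers for weaker inhibition of growth. Compound 1 `Cc1ccccc1Nc1nc(Nc2ccccc2)ncc1Cl` reports only a limit, > 100000 nM. Compound 2 `Cc1ccccc1Nc1nc(Nc2ccc(N3CCN(C)CC3)cc2)ncc1Cl` gives 7020 nM, and compound 3 `Cc1ccccc1Nc1nc(Nc2ccc(N3CCCCC3)cc2)ncc1Cl` gives 19900 nM. Compound 3 therefore has the higher of the two actual numbers, and compound 2 is its nearest neighbour.

Compound 4 `Cc1ccccc1Nc1nc(Nc2ccc(N3CCCN(C)CC3)cc2)ncc1Cl` is not yet measured. It carries 4-methyl-1,4-diazepan-1-yl in place of piperidin-1-yl on an aromatic carbon.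

Going by the values given here, three measured steps bear on this change. The two that start from the limit (the limit of > 100000 nM in this assay, at which 1 of the 3 values shown sits) are an at least 14-fold lower number from compound 1 to compound 2 (1.15 log units; beyond the scatter), which is large, and an at least 5.0-fold lower number from compound 1 to compound 3 (0.70 log units; beyond the scatter), which is at least modest. Both show the direction of adding a ring group, but neither fixes a size. The closest guide is a 2.8-fold higher number from compound 2 to compound 3 (0.45 log units; beyond the scatter), a modest step beyond the scatter, since the incoming group resembles the 4-methylpiperazin-1-yl of compound 2 by name more than piperidin-1-yl does. No seven-membered ring has been tested yet, so the range stays wide.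

A modest step towards a lower number is expected in this assay, estimated as a 2.5-fold lower number from compound 3 to compound 4 (0.40 log units; beyond the scatter). For compound 4 the expected value is 8000 nM, with an estimated range of 2800 nM to 22000 nM.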

Compound 4, concentration for 50% growth inhibition: 6390 nM
Estimate against measurement, compound 4: 1.3-fold (0.10 log units) above; measured number inside the range.
By their numbers in this assay, from the lowest: compounds 4 and 2 (each within the scatter of the next); then compound 3. At a limit, above all of these: compound 1.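

In this assay, this aromatic carbon, para to a large group, takes a seven-membered non-aromatic ring as readily as a six-membered one when the second ring nitrogen and its methyl are kept: a 1.1-fold lower number from compound 2 to compound 4 (0.04 log units; within the scatter), so 4-methyl-1,4-diazepan-1-yl and 4-methylpiperazin-1-yl cannot be told apart here. Against piperidin-1-yl the change is a real one, a 3.1-fold lower number from compound 3 to compound 4 (0.49 log units; beyond the scatter), which places compound 3 apart from both compounds with 2 hetero atoms in the ring, and no compound shown goes against this split. The step from the unsubstituted compound, an at least 15-fold lower number from compound 1 to compound 4 (1.19 log units; beyond the scatter), gives only a bound on its size, as compound 1 reports a limit: the limit of > 100000 nM in this assay, at which 1 of the 4 values shown sits.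

As far as these compounds go, whether the second ring nitrogen or its methyl goes with the lower numbers stays open, and a morpholin-4-yl or a piperazin-1-yl without the methyl at this place would separate the two. Also open, from the compounds shown here alone, is whether a longer chain carrying a dimethylamine, with no ring at all, would read like compound 2 and compound 4 or like compound 3.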